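The source may report more compounds than this note shows. Statements on the series, on what has been measured and on what is new or still open speak of the compounds shown alone.

Of the compounds shown here, three sharing one core have been tested in a functional assay on A549 cells (Homo sapiens) for cytotoxicity, read by MTT assay; a lower number here means a stronger inhibitor, a higher number a weaker inhibitor. In this assay compound 1 `COc1ccc(-c2oc3c(CC=C(C)C)c(OC(C)C(=O)O)cc(O)c3c(=O)c2O)cc1` gives 15300 nM, while compound 3 `COc1ccc(-c2oc3c(CC=C(C)C)c(OCCCOC(=O)CCC(=O)O)cc(O)c3c(=O)c2OCCCOC(=O)CCC(=O)O)cc1` gives 18400 nM. These two numbers lie within the usual scatter of each other, so compound 1 stands level with compound 3. For compound 2 `COc1ccc(-c2oc3c(CC=C(C)C)c(OC(C)C(=O)O)cc(O)c3c(=O)c2OC(C)C(=O)O)cc1` the assay reports only a limit, > 100000 nM; > 100000 nM (2 entries).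

Compound 4 `CCOC(=O)COc1cc(O)c2c(=O)c(O)c(-c3ccc(OC)cc3)oc2c1CC=C(C)C` has not yet been measured. It departs from compound 1 on an oxygen on an aromatic ring, where (ethoxycarbonyl)methyl stands in place of 1-carboxyethyl: (ethoxycarbonyl)methyl in place of 1-carboxyethyl on an oxygen on an aromatic ring. The rest of the structure of compound 1 is kept.

Within the data shown here, no measured pair shows this change on its own, so the data favour no direction. The expectation therefore rests on compound 1 at 15300 nM, with no shift beyond the scatter anticipated in this assay. The expected change is a 1.3-fold higher number from compound 1 to compound 4 (0.12 log units; within the scatter). Compound 4 is estimated at 20000 nM, with an expected range of 7000 nM to 60000 nM.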

Compound 4, half-maximal inhibitory concentration: 41600 nM
Compound 4: middle estimate off by 2.1-fold (0.32 log units), on the low side, within the range that was stated.
By their numbers in this assay, from the lowest: compounds 1 and 3 (each within the scatter of the next); then compound 4.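

In this assay, placing (ethoxycarbonyl)methyl in place of 1-carboxyethyl on an oxygen on an aromatic ring gives a 2.7-fold higher number from compound 1 to compound 4 (0.43 log units; beyond the scatter) as a modest step beyond the scatter. Among these compounds, this is the first reading of a change at this position alone, and it shows that the number responds to the group held there, though only this one pair speaks to it. Nothing measured here accounts for the step. The swap alters two features at once, an ethyl ester replacing a carboxylic acid and a methyl branch going, so the compounds shown leave open which of them carries the step. A carboxymethyl or a 1-(ethoxycarbonyl)ethyl group on the same oxygen would separate the two, and an amide there remains an open question as well.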